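This account rests on a few compounds, and the source may have more. Where it says the series, first, only, none or still open, it means among the compounds named here.

Compound 1, `CC(O)(CSc1cccc(S(F)(F)(F)(F)F)c1)C(=O)Nc1cccc(S(F)(F)(F)(F)F)c1`, was examined in a functional assay on VCaP cells (Homo sapiens) for antiproliferative activity, read by propidium iodide staining, with a stated time of 96 h (on this read-out lower numbers stand for stronger inhibition and higher numbers for weaker inhibition), where compound 1 gives 29000 nM. Compound 2, `CC(O)(CSc1cccc(OC(F)(F)F)c1)C(=O)Nc1cccc(S(F)(F)(F)(F)F)c1`, differs from it in one place: a group of 5 heavy atoms (1 carbon, 1 oxygen, 3 fluorine; no ring) in place of a group of 6 heavy atoms (5 fluorine, 1 sulfur; no ring), on an aromatic carbon. In this assay compound 2 gives 17500 nM, so the change made a 1.7-fold lower number from compound 1 to compound 2 (0.22 log units; within the scatter).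

Compound 3, `CC(O)(COc1ccc(S(F)(F)(F)(F)F)cc1)C(=O)Nc1ccc(S(F)(F)(F)(F)F)cc1`, shares the same kind of skeleton but the difference between its core and the core of compound 1 is not broken down here. In this assay compound 3 gives 9300 nM. Its number is the lowest of the three: the number of compound 2 lies within the usual scatter of it, while the number of compound 1 lies beyond that scatter.

Compound 4, `CC(O)(COc1ccc(OC(F)(F)F)cc1)C(=O)Nc1ccc(S(F)(F)(F)(F)F)cc1`, has not yet been measured. It stands to compound 3 as compound 2 stands to compound 1: a group of 5 heavy atoms (1 carbon, 1 oxygen, 3 fluorine; no ring) in place of a group of 6 heavy atoms (5 fluorine, 1 sulfur; no ring), on an aromatic carbon. Among the compounds with values here, this is the same kind of change as the one from compound 1 to compound 2, though not the same, since in that pair the group sits meta to a large group and here it sits para to a large group. Because the earlier step was a 1.7-fold lower number from compound 1 to compound 2 (0.22 log units; within the scatter), the step from compound 3 to compound 4 in this assay is expected to be of similar size, a 1.7-fold lower number from compound 3 to compound 4 (0.23 log units; within the scatter), and to stay within the usual scatter. On that basis compound 4 is estimated to give 5500 nM, with a range from 2500 nM to 12000 nM.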

Compound 4, half-maximal inhibitory concentration: 12800 nM
Compound 4: middle estimate off by 2.3-fold (0.37 log units), on the low side; measured number above the stated range.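

In this assay, within the data shown here, putting trifluoromethoxy in place of the group of five fluorine atoms on sulfur gave a 1.4-fold higher number from compound 3 to compound 4 (0.14 log units; within the scatter), so on the core of compound 3, as on the core of compound 1, the swap produced no step that can be told from the scatter. Although the two steps are printed with opposite signs, they cannot be told apart either: the same change on two cores in this assay, a 1.7-fold lower number (0.22 log units; within the scatter) from compound 1 to compound 2 and a 1.4-fold higher number (0.14 log units; within the scatter) from compound 3 to compound 4, 2.3-fold (0.36 log units) apart, within the scatter of two such steps This shows that, on these two cores, the two groups are interchangeable as far as this read-out can tell, but it does not show a reliable direction for the change, a real difference between the cores, or that the same would hold on any further core, since a single pair on each core is all that is available.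

As far as these compounds go, it remains open what a nitrile, a chlorine atom or an amine on that aromatic carbon would give in this assay, and whether any replacement there would produce a step beyond the scatter. Also open, from the compounds shown here alone, is how the same swap would behave on the other aromatic ring, the one on the amide nitrogen, which carries the group of five fluorine atoms on sulfur in all four compounds.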